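Swapping furan-2-yl for 4-cyanophenyl on the amide carbonyl

The compounds below may be only part of what the source reports. "The series", "measured", "known", "first", "only" and "open" are said of these compounds alone.

In a functional assay on KB cells (Homo sapiens) for cytotoxicity (on this read-out higher numbers stand for weaker inhibition and lower numbers for stronger inhibition), compound 3 (`COc1ccc(S(=O)(=O)N2CCc3cccc(NC(=O)c4ccco4)c32)cc1`) gives 9.6 nM, the lowest number of the three measured compounds. Compound 1 (`COc1ccc(S(=O)(=O)N2CCc3cccc(NC(=O)c4ccc(F)cc4)c32)cc1`) gives 93 nM, and compound 2 (`COc1ccc(S(=O)(=O)N2CCc3cccc(NC(=O)c4ccccc4)c32)cc1`) gives 297 nM.

The next structure, compound 4 (`COc1ccc(S(=O)(=O)N2CCc3cccc(NC(=O)c4ccc(C#N)cc4)c32)cc1`), has 4-cyanophenyl in place of furan-2-yl on a carbonyl carbon.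

The closest precedents run the opposite way, with furan-2-yl entering at that same carbon: a 31-fold lower number from compound 2 to compound 3 (1.49 log units; beyond the scatter) and a 9.7-fold lower number from compound 1 to compound 3 (0.99 log units; beyond the scatter). Both are beyond the scatter. The remaining step, a 3.2-fold higher number from compound 1 to compound 2 (0.50 log units; beyond the scatter), shows that a change on the aromatic ring alone can also move the number, but no nitrile has been measured in this series.

Leaving furan-2-yl is therefore expected to raise the number in this assay, by a modest to large step. The expected change is a 16-fold higher number from compound 3 to compound 4 (1.19 log units; beyond the scatter). For compound 4 the estimated value is 150 nM, with an expected range of 40 nM to 550 nM.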

Compound 4, half-maximal inhibitory concentration: 105 nM
The estimate for compound 4 lay 1.4-fold (0.15 log units) above the measured number; the measured number falls inside the stated range.
By their numbers in this assay, from the lowest: compound 3; then compounds 1 and 4 (each within the scatter of the next); then compound 2.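

In this assay, an 11-fold higher number from compound 3 to compound 4 (1.04 log units; beyond the scatter) shows that the lower number with furan-2-yl on the carbonyl carbon holds against a nitrile-bearing phenyl as well as against phenyl and 4-fluorophenyl. On the aromatic carbon, cyano in place of hydrogen gives a 2.8-fold lower number from compound 2 to compound 4 (0.45 log units; beyond the scatter) and so lowers the number much as fluoro does, while cyano in place of fluoro gives a 1.1-fold higher number from compound 1 to compound 4 (0.05 log units; within the scatter) and leaves the two substituents indistinguishable. Nothing available explains these steps.

Open, going by these compounds, is whether the low number belongs to furan-2-yl itself or extends to other five-membered aromatic rings, such as thiophen-2-yl. Also open, on these data alone, is whether an amine or a carboxylic acid on the same aromatic carbon would match fluoro and cyano.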